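A Phenyl Ring Replaces the Amide-Bearing Chain

The source may report more compounds than this note shows. Statements on the series, on what has been measured and on what is new or still open speak of the compounds shown alone.

Compound 3 `COC(=O)/C=C/c1cccc(N(Cc2ccc(/C=C/C(=O)NC(C)(C)C)cc2)C(=O)C2CCCCC2)c1` shares its core with compound 1 `CCOC(=O)/C=C/c1ccc(CN(C(=O)C2CCCCC2)c2cccc(/C=C/C(=O)OC)c2)cc1` and compound 2 `COC(=O)/C=C/c1cccc(N(Cc2ccc(/C=C/C(=O)OCc3ccccc3)cc2)C(=O)C2CCCCC2)c1`. In an assay on isolated protein with Bile acid receptor (Homo sapiens) as the target (a higher number here means that more compound is needed for the effect, a lower number that less compound is needed), compound 3 gives > 1000 nM, which is a limit of the assay rather than a number. Compound 1 likewise gives only a limit, > 1000 nM. Compound 2 also reaches only a limit, > 1000 nM. Thus (the limit of > 1000 nM in this assay, at which 3 of the 3 values shown sit), and compound 3 stands at the same limit as the other two. The three steps among them, a step that the two limits leave unreadable from compound 1 to compound 2, a step that the two limits leave unreadable from compound 1 to compound 3 and a step that the two limits leave unreadable from compound 2 to compound 3, each run from one limit to another and have no readable size. Compound 4 `COC(=O)/C=C/c1cccc(N(Cc2ccc(-c3ccc(SC)cc3)cc2)C(=O)C2CCCCC2)c1` is reached from compound 3 by 4-(methylsulfanyl)phenyl in place of 2-((tert-butyl)carbamoyl)ethenyl on an aromatic carbon. Going by the values given here, none of the measured steps concerns this kind of exchange; they show only that swapping ethoxy, benzyloxy or (tert-butyl)amino on a carbonyl carbon left every compound at the limit. Among the compounds with values here, the expected step from compound 3 to compound 4, a step that the limit leaves unreadable from compound 3 to compound 4, therefore rests on no measured step and is an estimate without a readable direction. Compound 4 is expected to show 2000 nM, within a range from 300 nM to 10000 nM.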

Compound 4, half-maximal effective concentration: 69 nM
Estimate against measurement, compound 4: 29-fold (1.46 log units) above; the whole stated range lies above it.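

In this assay, placing 4-(methylsulfanyl)phenyl on this aromatic carbon, para to a large group, gives an at least 14-fold lower number from compound 3 to compound 4 (1.16 log units; beyond the scatter), and the same exchange from the other two compounds gives an at least 14-fold lower number from compound 2 to compound 4 (1.16 log units; beyond the scatter) and an at least 14-fold lower number from compound 1 to compound 4 (1.16 log units; beyond the scatter). Going by these compounds alone, the earlier swaps on the carbonyl carbon of the chain cannot be read, so this is the first sign that the group at this position can shift the number at all, and that removing the whole chain in favour of an aromatic ring brings a compound inside the readable range. These steps give only a minimum size because the starting compounds sit at a limit: the limit of > 1000 nM in this assay, at which 3 of the 4 values shown sit.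

The compounds shown do not separate the share of the phenyl ring from that of the methylsulfanyl group on it. An unsubstituted phenyl, or a 4-methoxyphenyl or 4-carboxyphenyl at the same place, would tell these apart.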